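The compounds below may be only part of what the source reports. "The series", "measured", "known", "first", "only" and "open" are said of these compounds alone.

The set comprises three measured compounds and one still to be measured. Compound 1 `O=C(CCCCCCc1ccccc1)c1nncs1` and compound 2 `COc1coc(C(=O)CCCCCCc2ccccc2)n1` share a seven-carbon chain ending in a phenyl group; in an assay on HEK-293T cells for inhibition of diacylglycerol lipase-alpha (Homo sapiens), read by colorimetric assay (on this read-out lower numbers stand for stronger inhibition and higher numbers for weaker inhibition), compound 1 gives > 10000 nM, which is a limit of the assay and not a number. Compound 2 likewise gives > 10000 nM in this assay, again a limit. Going by the values given here, the one measured step, a step that the two limits leave unreadable from compound 1 to compound 2, therefore offers no size to read, and both values sit at the limit of > 10000 nM in this assay, at which 2 of the 3 values shown sit. Compound 3 `O=C(CCCCCCc1ccccc1)c1ncc(C(=O)C(F)(F)F)o1` alone yields a number, 1820 nM in this assay, and so it stands as the only fixed point among the values shown. Compound 4 `O=C(CCCCCCc1ccccc1)c1ncc(Cl)o1` differs from compound 3 by chloro in place of (trifluoromethyl)carbonyl on an aromatic carbon. Among the compounds with values here, no measured step covers this change; what is known is that compound 3, which carries the (trifluoromethyl)carbonyl, gives a number while the two compounds without it reach only the limit. Compound 4 is therefore expected to lose potency in this assay, with an estimated value of 10000 nM, ranging from 3000 nM to 30000 nM, and quite possibly reported only as a limit. The step of a 5.5-fold higher number from compound 3 to compound 4 (0.74 log units; beyond the scatter) is expected to lie beyond the scatter, toward weaker inhibition.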

Compound 4, half-maximal inhibitory concentration: > 10000 nM
Compound 4 gave a limit, no number; the forecaster's own chance of this, stated with the estimate: 65%; the middle value lies on the limit itself.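

Going by these compounds alone, with the rest of compound 3 kept, chloro in place of (trifluoromethyl)carbonyl on the aromatic carbon next to the ring oxygen gives an at least 5.4-fold higher number from compound 3 to compound 4 (0.73 log units; beyond the scatter) in this assay, the first readable step in the set and the first to change one group on an otherwise unchanged core. Compound 4 gives a limit and not a number, so this size is only a minimum. The steps linking compound 4 to compound 1 and compound 2 cannot be read, and the set now gathers at one limit: the limit of > 10000 nM in this assay, at which 3 of the 4 values shown sit.

The compounds shown leave open whether a nitrile, a methyl ester or an amide on this aromatic carbon would give a number in this assay. They also leave open whether a shorter chain in place of the seven-carbon chain would change the value of compound 3.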